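From dichlorophenyl to tert-butylphenyl on the sulfonyl sulfur

This account rests on a few compounds, and the source may have more. Where it says the series, first, only, none or still open, it means among the compounds named here.

Two related compounds have so far been tested in a functional assay on HepG2 cells (Homo sapiens) for antiproliferative activity, read by MTT assay, with a stated time of 48 h; a higher number here means a weaker inhibitor, a lower number a stronger inhibitor. Compound 1 `Cc1ccc(S(=O)(=O)n2cc(/C=C/C(=O)c3ccncc3)c3ccccc32)cc1` gives 44800 nM, and compound 2 `O=C(/C=C/c1cn(S(=O)(=O)c2ccc(Cl)cc2Cl)c2ccccc12)c1ccncc1` gives 14800 nM, the lower number of the two and therefore the stronger result. Compound 3 `CC(C)(C)c1ccc(S(=O)(=O)n2cc(/C=C/C(=O)c3ccncc3)c3ccccc32)cc1` keeps the shared core but has 4-(tert-butyl)phenyl in place of 2,4-dichlorophenyl on a sulfonyl sulfur.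

For the measured compounds named here, only one measured step bears on this change. It is a 3.0-fold lower number from compound 1 to compound 2 (0.48 log units; beyond the scatter), a modest improvement beyond the scatter that accompanied the swap of 4-methylphenyl for 2,4-dichlorophenyl. Compound 3 gives up that 2,4-dichlorophenyl, and its 4-(tert-butyl)phenyl looks more like the 4-methylphenyl of compound 1. Going by the values given here, no tested compound carries 4-(tert-butyl)phenyl, however, so this single step is thin evidence. Some of the improvement is therefore expected to be lost, pointing towards a higher number in this assay. The expected step is a 2.0-fold higher number from compound 2 to compound 3 (0.31 log units; beyond the scatter), which is modest in size. For compound 3 the estimated value is 30000 nM, with an expected range from 11000 nM to 70000 nM.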

Compound 3, half-maximal inhibitory concentration: 27000 nM
Estimate against measurement, compound 3: 1.1-fold (0.05 log units) above; the range from low to high includes it.
By their numbers in this assay, from the lowest: compounds 2, 3 and 1 (each within the scatter of the next, the first and the last beyond it).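

In this assay, replacing 2,4-dichlorophenyl with 4-(tert-butyl)phenyl on the sulfonyl sulfur gives a 1.8-fold higher number from compound 2 to compound 3 (0.26 log units; within the scatter), while replacing methyl with tert-butyl on an aromatic carbon gives a 1.7-fold lower number from compound 1 to compound 3 (0.22 log units; within the scatter). Both steps lie within the scatter, so compound 3 cannot be told apart from either compound 1 or compound 2, even though those two are separated by more than the scatter; the chlorine-free 4-(tert-butyl)phenyl group therefore gives a result that cannot be distinguished from that of the 2,4-dichlorophenyl group, but the same is true of its comparison with 4-methylphenyl. No measurement shown here explains why the numbers fall as they do.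

Still open, on these data alone, is whether the difference between compound 1 and compound 2 comes from the two chlorines together, since a phenyl ring carrying a single chlorine would be needed to separate their contributions. It is also unknown how an amine or a carboxylic acid in place of tert-butyl on the aromatic carbon would change the number in this assay.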